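This account rests on a few compounds, and the source may have more. Where it says the series, first, only, none or still open, it means among the compounds named here.

Measured compounds:
- compound 1 `Cc1ccc(S(=O)(=O)NCc2cn(C[C@H](O)[C@H]3OC(=O)C(OCc4ccccc4)=C3OCc3ccccc3)nn2)cc1`: 6400 nM in a functional assay on MCF7 cells (Homo sapiens) for antiproliferative activity, read by MTT assay, with a stated time of 72 h; a higher number here means a weaker inhibitor, a lower number a stronger inhibitor
- compound 2 `O=C1O/C(=C\Cn2cc(-c3ccc(Br)cc3)nn2)C(OCc2ccccc2)=C1OCc1ccccc1`: in this assay compound 2 gives only a limit, > 100000 nM
- compound 3 `CCCCCc1ccc(-c2cn(C/C=C3\OC(=O)C(OCc4ccccc4)=C3OCc3ccccc3)nn2)cc1`: in this assay compound 3 likewise gives only a limit, > 100000 nM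

Compound 1 is the only one of the three that gives a number in this assay; the other two sit at the limit of > 100000 nM in this assay, at which 2 of the 3 values shown sit. Among the measured compounds shown here, the one change that can be read between measured compounds, a step that the two limits leave unreadable from compound 2 to compound 3, runs between two limits, so its size cannot be told. Compound 4 `CCCCCc1ccc(-c2cn(C[C@H](O)[C@H]3OC(=O)C(OCc4ccccc4)=C3OCc3ccccc3)nn2)cc1` keeps the core of compound 1 and differs from it by 4-pentylphenyl in place of (((4-methylphenyl)sulfonyl)amino)methyl on an aromatic carbon. For the measured compounds named here, no measured pair on the core of compound 1 shows this change, and the pair of compound 2 and compound 3 carries the 4-pentylphenyl group on a different core where both values are limits, so it gives no readable guide. The expected step of a 1.9-fold higher number from compound 1 to compound 4 (0.27 log units; within the scatter) is therefore uncertain in size and direction, with some chance that compound 4 also reaches only a limit. Compound 4 is estimated at 12000 nM, within a range from 3000 nM to 60000 nM.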

Compound 4, half-maximal inhibitory concentration: 9010 nM
Compound 4: the middle estimate sits 1.3-fold (0.12 log units) above what was measured; low and high end bracket the measured number.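

On the core of compound 1, this assay shows a 1.4-fold higher number from compound 1 to compound 4 (0.15 log units; within the scatter). This aromatic carbon therefore carries either 4-pentylphenyl or (((4-methylphenyl)sulfonyl)amino)methyl with values that lie within the scatter of each other, although the entering group has no hydrogen-bond donor or acceptor and the leaving group has both. Before this result, the 4-pentylphenyl group had been seen only on a different core, where the value is a limit and not a number: the limit of > 100000 nM in this assay, at which 2 of the 4 values shown sit.

The compounds shown leave open what an amine, a carboxylic acid or a shorter chain such as butyl would give at this position in this assay. They also leave open how a methoxy group in place of the hydroxyl on the core of compound 4 would read.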